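The source may hold more compounds than are shown below. What is called first, only, known or untested is meant among the compounds shown, and "the series" means these compounds.

Measured so far:
compound 1 `N#Cc1ccc(F)c(OC(=O)N2CCC(C(c3ccccc3)c3ccccc3)CC2)c1`, 112 nM
compound 2 `COc1cc(C#N)cc(OC(=O)N2CCC(C(c3ccccc3)c3ccccc3)CC2)c1`, 98 nM

In an assay on isolated protein for inhibition of Monoglyceride lipase (Rattus norvegicus), read by fluorescence, with stated times of 15 min and 3 h (on this read-out higher numbers stand for weaker inhibition and lower numbers for stronger inhibition), compound 1 gives 112 nM and compound 2 gives 98 nM; the two lie within the scatter of each other, so neither can be set above the other. Within the data shown here, the only measured step, a 1.1-fold lower number from compound 1 to compound 2 (0.06 log units; within the scatter), exchanges one substituted aromatic ring on the oxygen next to a carbonyl group for another and moves the number by less than the scatter. Compound 3 `Cc1cc(C#N)cc(OC(=O)N2CCC(C(c3ccccc3)c3ccccc3)CC2)c1` is not yet measured. It differs from compound 2 by methyl in place of methoxy on an aromatic carbon. Among the measured compounds shown here, no measured step bears directly on this exchange; the one step available shows that a change on this ring left the number essentially unmoved. The step from compound 2 to compound 3 is therefore expected to stay within the scatter, a 1.1-fold higher number from compound 2 to compound 3 (0.05 log units; within the scatter). Compound 3 is estimated at 110 nM in this assay, with a range of 45 nM to 270 nM.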

Compound 3, half-maximal inhibitory concentration: 150 nM
Compound 3: middle estimate off by 1.4-fold (0.13 log units), on the low side; the measured number falls inside the stated range.
By their numbers in this assay, from the lowest: compounds 2, 1 and 3 (each within the scatter of the next).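

In this assay, methyl in place of methoxy, meta to a cyano group, gives a 1.5-fold higher number from compound 2 to compound 3 (0.18 log units; within the scatter), so this position accepts a direct exchange of methoxy for a group without oxygen with no step beyond the scatter. The comparison of ring patterns on the oxygen next to the carbonyl gives a 1.3-fold higher number from compound 1 to compound 3 (0.13 log units; within the scatter), which means the three rings shown cannot be put in any order on this read-out. Nothing measured here accounts for these small steps.

As far as these compounds go, whether an amine, a carboxylic acid or a longer chain such as butoxy at this position would move the number beyond the scatter remains open. From the compounds shown here alone, all three compounds also keep the cyano group and the shared core, so the contribution of each of these remains open as well.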